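Changing the Cap on Compound 2: What to Expect

The source may report more compounds than this note shows. Statements on the series, on what has been measured and on what is new or still open speak of the compounds shown alone.

Of the compounds shown here, two have so far been measured in a functional assay on HOP-62 cells (Homo sapiens) for antiproliferative activity; on this read-out lower numbers stand for stronger inhibition and higher numbers for weaker inhibition. Compound 1 `O=C(CCCCC[C@H](NC(=O)c1ccc(Br)cc1)C(=O)Nc1ccc(-c2ccccc2)cc1)NO` gives 261 nM. Compound 2 `CN(C)c1ccc(C(=O)N[C@@H](CCCCCC(=O)NO)C(=O)Nc2cccc3cccnc23)cc1` gives 137 nM, the lower of the two numbers, although the gap to compound 1 lies within the usual scatter of repeated measurements, so the two compounds cannot be told apart on the present evidence.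

Compound 3 `O=C(/C=C/c1ccccc1)N[C@@H](CCCCCC(=O)NO)C(=O)Nc1cccc2cccnc12` has not been measured yet. It keeps the shared core of compound 2 and differs from it in a single place: 2-phenylethenyl in place of 4-(dimethylamino)phenyl on a carbonyl carbon

Among the compounds with values here, no pair of measured compounds differing only at this place is available, so there is no measured step to show how such a change moves the numbers in this assay. Without such guidance, only a modest step is expected from compound 2 to compound 3 in this assay, of size a 1.6-fold higher number from compound 2 to compound 3 (0.21 log units; within the scatter), leaning if anything toward weaker inhibition. Compound 3 is accordingly estimated to come out near 220 nM, with a likely range from 80 nM to 600 nM.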

Compound 3, half-maximal inhibitory concentration: 65 nM
Compound 3: the middle estimate sits 3.4-fold (0.53 log units) above what was measured; measured number outside the range, below it.
By their numbers in this assay, from the lowest: compound 3; then compounds 2 and 1 (each within the scatter of the next).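

In this assay, the group on this carbonyl carbon proves able to shift the result: putting 2-phenylethenyl in place of 4-(dimethylamino)phenyl gives a 2.1-fold lower number from compound 2 to compound 3 (0.32 log units; beyond the scatter), the first difference in this set that rises above the scatter. Inhibition at this level therefore does not depend on the 4-(dimethylamino)phenyl group, and the change, which removes a nitrogen and a hydrogen-bond acceptor and adds a double bond outside the aromatic ring, leads to stronger inhibition rather than weaker. A single step cannot show which part of this change matters, and nothing available explains the shift.

The compounds shown leave open whether the double bond matters or whether the gain comes from losing the dimethylamino group; 2-phenylethyl and plain phenyl on the same carbonyl carbon would help separate these two possibilities. Also unresolved is how this position would respond to a group of another kind, such as a carboxylic acid or an amine on the phenyl ring of 2-phenylethenyl, or whether the same change would give a similar step on the core of compound 1.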